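Phenyl to 4-nitrophenyl on compound 2

A few compounds are considered here, and "the series" means these few. Any claim that something is new, unique, unknown or untested is made for them only; others in the source may bear on it.

Measured in a functional assay on NAMALVA cells (Homo sapiens) for inhibition, with a stated time of 72 h; on this read-out higher numbers stand for weaker inhibition and lower numbers for stronger inhibition:
- compound 1 `CNC(=O)C1=C[C@@H]2[C@@H](C(C)C)CC[C@@]3(CO3)[C@H]2C(=O)OC1`: 1280 nM
- compound 2 `CC(C)[C@H]1CC[C@@]2(CO2)[C@H]2C(=O)OCC(C(=O)OCc3ccc(-c4ccccc4)o3)=C[C@H]12`: 370 nM
- compound 3 `CC(C)[C@H]1CC[C@@](O)(CCl)[C@H]2C(=O)OCC(C(=O)OCc3ccc(-c4ccccc4)o3)=C[C@H]12`: 1110 nM

Compound 2 has the lowest number of the three, and its gaps to compound 3 and compound 1 both lie beyond the scatter. Compound 4 `CC(C)[C@H]1CC[C@@]2(CO2)[C@H]2C(=O)OCC(C(=O)OCc3ccc(-c4ccc([N+](=O)[O-])cc4)o3)=C[C@H]12` changes phenyl to 4-nitrophenyl, with nitro in place of hydrogen on an aromatic carbon, para to a large group (nitro in place of hydrogen on an aromatic carbon). Within the data shown here, no measured pair here isolates a comparable change, so the size of the step rests on judgement alone. The estimated step is a 1.1-fold higher number from compound 2 to compound 4 (0.03 log units; within the scatter), not expected to exceed the scatter in this assay, and no firm direction is expected. Compound 4 is expected at 400 nM, with an estimated range of 150 nM to 1100 nM.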

Compound 4, half-maximal inhibitory concentration: 1190 nM
Estimate against measurement, compound 4: 3.0-fold (0.47 log units) below, outside the stated range (above it).
By their numbers in this assay, from the lowest: compound 2; then compounds 3, 4 and 1 (each within the scatter of the next).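

On the phenyl of compound 2, the place para to a large group is not indifferent in this assay: nitro in place of hydrogen gives a 3.2-fold higher number from compound 2 to compound 4 (0.51 log units; beyond the scatter) and so costs inhibition. The change adds a nitro group at this one place and leaves the rest of the molecule untouched, so the loss belongs to this substitution. Nothing at hand accounts for the step.

Open, on these data alone, is whether an amine or a methoxy group at the same place would track compound 2 or compound 4. Also open, as far as these compounds go, is whether the same step would hold on the chlorohydrin of compound 3.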